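Trichloromethyl for methyl on the shared sulfur-containing core

The compounds below may be only part of what the source reports. "The series", "measured", "known", "first", "only" and "open" are said of these compounds alone.

Of the compounds shown here, two have so far been tested in an ADME assay for inhibition of prostaglandin G/H synthase 1 (Rattus norvegicus), with a stated time of 30 min; a lower number here means a stronger inhibitor, a higher number a weaker inhibitor. Compound 1, with the structure `CN1C=CN(C2OC(C(Cl)(Cl)Cl)=CN2c2ccc(S(N)(=O)=O)cc2)C=C1`, gives 53400 nM. Compound 2, with the structure `CC1=CN(c2ccc(S(N)(=O)=O)cc2)C(N2C=CN(C)C=C2)S1`, gives 76900 nM. Compound 2 has the highest of the two numbers, but its nearest neighbour is compound 1, and the gap between the two values lies within the usual scatter, so the two compounds cannot be told apart on these data.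

Compound 3, with the structure `CN1C=CN(C2SC(C(Cl)(Cl)Cl)=CN2c2ccc(S(N)(=O)=O)cc2)C=C1`, has not yet been measured. It differs from compound 2 by one change: trichloromethyl in place of methyl on a double-bonded ring carbon. Compound 3 also carries the same trichloromethyl group as compound 1, while keeping the ring sulfur of compound 2.

Among the compounds with values here, no step between measured compounds is available, so there is no guide to the size of this change. Both measured compounds sit at weak inhibition, and compound 3 is expected to stay in the same region, with a step of a 1.4-fold lower number from compound 2 to compound 3 (0.15 log units; within the scatter) that is not expected to go beyond the scatter. For compound 3 the estimate in this assay is 55000 nM, within a range of 15000 nM to 200000 nM.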

Compound 3, half-maximal inhibitory concentration in the prostaglandin G/H synthase 1 assay: 88600 nM
For compound 3 the middle estimate is 1.6-fold (0.21 log units) below the measured one; the range from low to high includes it.
By their numbers in the prostaglandin G/H synthase 1 assay, from the lowest: compounds 1, 2 and 3 (each within the scatter of the next).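

In the prostaglandin G/H synthase 1 assay, trichloromethyl in place of methyl on a double-bonded ring carbon gives a 1.2-fold higher number from compound 2 to compound 3 (0.06 log units; within the scatter), so the two compounds cannot be told apart there, even though the entering group holds more heavy atoms than the one it replaces. Within the data shown here, this position therefore accepts the larger group without any readable effect on the inhibition number, which the earlier compounds could not show, as no pair among them differed by this change alone. In a physicochemical assay for lipophilicity (a higher number here means a more lipophilic compound, a lower number a more polar compound), compound 2 gives 1.75 and compound 3 gives 3.13, so the same change that leaves inhibition unreadable makes the compound clearly more lipophilic, as measured: the measured partition coefficient of compound 2, 1.75, and of compound 3, 3.13, a number 1.38 log units higher (beyond the scatter)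

All of these compounds remain at weak inhibition, and two groups at one position cannot show whether any substituent on this ring carbon would move the number in the prostaglandin G/H synthase 1 assay beyond the scatter. A polar group in the same place, such as a carboxylic acid or an amine, remains an open case for both the inhibition number and the partition coefficient.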